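The source may report more compounds than this note shows. Statements on the series, on what has been measured and on what is new or still open speak of the compounds shown alone.

Within the data shown here, in a functional assay on L02 cells (Homo sapiens) for inhibition, read by Griess assay, with stated times of 1 h and 24 h (a higher number here means a weaker inhibitor, a lower number a stronger inhibitor), every value so far is a limit of the assay rather than a number. Compound 1 `COc1cc(/C=C/c2nccc(NC(C)C)n2)cc(OC)c1OC` gives < 40000 nM, a limit. Compound 2 `COc1cc(/C=C/c2nc(O)nc(NC(C)C)n2)cc(OC)c1OC` gives < 40000 nM, also a limit. Compound 3 `COc1cc(/C=C/c2nc(N(C)C)c3sccc3n2)cc(OC)c1OC` gives > 1000000 nM, again a limit, so its position is bounded but not fixed by a number. Compound 4 `COc1cc(/C=C/c2nc(N3CCN(C)CC3)c3sccc3n2)cc(OC)c1OC` carries 4-methylpiperazin-1-yl in place of dimethylamino on an aromatic carbon. Among the measured compounds shown here, no measured pair shows this change on its own, so any expectation is loose. Compound 3 reads > 1000000 nM, a limit, so the change is expected to move this assay only towards stronger inhibition. The estimated step is an at least 3.3-fold lower number from compound 3 to compound 4 (0.52 log units; beyond the scatter). For compound 4 the expected value is 300000 nM, with an estimated range of 30000 nM to 1500000 nM.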

Compound 4, half-maximal inhibitory concentration: > 1000000 nM
Compound 4 ended at the assay's limit; the forecaster's own chance of this, stated with the estimate: 55%; at least 3.3-fold (0.52 log units) between middle value and limit.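

In this assay compound 3 gives > 1000000 nM, a limit. Compound 4 gives > 1000000 nM, also a limit, so no step can be read between compound 3 and compound 4. The compounds shown leave open how far 4-methylpiperazin-1-yl in place of dimethylamino moves this read-out, if at all.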